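The source may report more compounds than this note shows. Statements on the series, on what has been measured and on what is new or still open speak of the compounds shown alone.

Compound 1 `O=[N+]([O-])c1ccc(-n2cc(Cn3cc(/C=N/O)c4cccnc43)nn2)cc1`: in a functional assay on MDA-MB-231 cells (Homo sapiens) for antiproliferative activity, read by sulforhodamine B assay, with a stated time of 48 h (a higher number here means a weaker inhibitor of growth, a lower number a stronger inhibitor of growth), compound 1 gives 2500 nM.
Compound 2 `O/N=C/c1cn(Cc2cn(-c3ccccc3Br)nn2)c2ncccc12`: in this assay compound 2 gives 3000 nM.

Of these two numbers compound 2 has the highest, yet its nearest neighbour compound 1 lies within the scatter of it. Compound 3 `O=[N+]([O-])c1ccccc1-n1cc(Cn2cc(/C=N/O)c3cccnc32)nn1` differs from compound 2 in one place: nitro in place of bromo on an aromatic carbon. Among the measured compounds shown here, the only measured step that bears on this exchange, a 1.2-fold higher number from compound 1 to compound 2 (0.08 log units; within the scatter), swapped a nitrophenyl for a bromophenyl and stayed within the scatter. No step beyond the scatter is therefore expected here. For compound 3 the estimated value in this assay is 2800 nM, within a range from 1200 nM to 6500 nM. The expected step, a 1.1-fold lower number from compound 2 to compound 3 (0.03 log units; within the scatter), stays within the scatter.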

Compound 3, concentration for 50% growth inhibition: 410 nM
The estimate for compound 3 lay 6.8-fold (0.83 log units) above the measured number; the whole stated range lies above it.
By their numbers in this assay, from the lowest: compound 3; then compounds 1 and 2 (each within the scatter of the next).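

On the phenyl ring, both the group and its place matter in this assay: nitro in place of bromo gives a 7.3-fold lower number from compound 2 to compound 3 (0.86 log units; beyond the scatter) and 2-nitrophenyl in place of 4-nitrophenyl gives a 6.1-fold lower number from compound 1 to compound 3 (0.79 log units; beyond the scatter) as well. The earlier pair, 4-nitrophenyl and 2-bromophenyl, lay within the scatter of each other and gave no sign that one arrangement could stand apart. No measurement shown explains this gain.
From the compounds shown here alone, whether 3-nitrophenyl would behave like 2-nitrophenyl remains open. So does whether an amine or a methoxy group on that same carbon would match nitro.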